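This account rests on a few compounds, and the source may have more. Where it says the series, first, only, none or still open, it means among the compounds named here.

Measured so far in a functional assay on MIA PaCa-2 cells (Homo sapiens) for inhibition, read by MTT assay, with a stated time of 7 days; on this read-out lower numbers stand for stronger inhibition and higher numbers for weaker inhibition:
- compound 1 `O=C([C@@H]1CCCN(S(=O)(=O)c2ccc(S(=O)(=O)N3CC[C@@H](O)C3)cc2)C1)N1CCC(F)(F)CC1`: 210 nM
- compound 2 `CCN(CC)S(=O)(=O)c1ccc(S(=O)(=O)N2CCC[C@@H](C(=O)N3CCC(O)CC3)C2)cc1`: 870 nM
- compound 3 `CCN(CC)S(=O)(=O)c1ccc(S(=O)(=O)N2CCC[C@@H](C(=O)N3CCC(OC)CC3)C2)cc1`: 140 nM

Compound 1 and compound 3 lie within the scatter of each other, and together they form the low end of these numbers. Within the data shown here, compound 2 stands apart, as the one measured step shows: a 6.2-fold lower number from compound 2 to compound 3 (0.79 log units; beyond the scatter).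

The next compound is compound 4 `CCN(CC)S(=O)(=O)c1ccc(S(=O)(=O)N2CCC[C@@H](C(=O)N[C@H]3CCOC3)C2)cc1`, which keeps the core of compound 3 and changes one group: (oxolan-3-yl)amino in place of 4-methoxypiperidin-1-yl on a carbonyl carbon. In words, (oxolan-3-yl)amino stands in place of 4-methoxypiperidin-1-yl on a carbonyl carbon.

Among the measured compounds shown here, only one measured step bears on this change, and it gives indirect guidance. Within the group that now leaves, a single small edit gave a 6.2-fold lower number from compound 2 to compound 3 (0.79 log units; beyond the scatter), a modest step but one beyond the scatter. This end of the molecule therefore does not look silent in this assay. For the measured compounds named here, no measured compound replaces the whole group, however, so neither size nor direction is secured. A modest rise is the working expectation, with a wide margin.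

An estimated 2.9-fold higher number from compound 3 to compound 4 (0.46 log units; beyond the scatter) is expected. For compound 4 the expected value in this assay is 400 nM, with an estimated range from 120 nM to 1300 nM.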

Compound 4, half-maximal inhibitory concentration: 1670 nM
Beside the measured number, compound 4's estimate is 4.2-fold (0.62 log units) below it; the measured number lies above the stated range.
By their numbers in this assay, from the lowest: compounds 3 and 1 (each within the scatter of the next); then compounds 2 and 4 (each within the scatter of the next).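

In this assay, the only whole-group replacement shown on this carbonyl carbon gives a large step (a 12-fold higher number from compound 3 to compound 4 (1.08 log units; beyond the scatter)), so this place tolerates the exchange of 4-methoxypiperidin-1-yl for (oxolan-3-yl)amino poorly. Measured against the 4-hydroxypiperidin-1-yl amide, the same entering group gives a step within the scatter (a 1.9-fold higher number from compound 2 to compound 4 (0.28 log units; within the scatter)), which leaves compound 3 apart from both compound 2 and compound 4 and shows that its low number depends on the intact 4-methoxypiperidin-1-yl group rather than on any amide at this place. Nothing available accounts for either step.

The change from compound 3 to compound 4 alters the ring size, adds the amide hydrogen and moves the ring oxygen in a single edit, and the compounds shown cannot separate these differences. Also open, as far as these compounds go, is how 4-ethoxypiperidin-1-yl, a morpholin-4-yl ring or the N-methyl form of (oxolan-3-yl)amino would read at this carbonyl carbon, and whether the methoxy gain from compound 2 to compound 3 extends to a longer ether chain.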